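This account rests on a few compounds, and the source may have more. Where it says the series, first, only, none or still open, it means among the compounds named here.

Compound 1 `CCCCc1ccc(CNCc2ccccc2)c(=O)n1Cc1ccc(-c2ccccc2-c2nn[nH]n2)cc1` gives 1 nM in a functional assay (aorta) for antagonist activity, with Oryctolagus cuniculus as the target; on this read-out lower numbers stand for stronger inhibition and higher numbers for weaker inhibition. Compound 2 `CCCCc1ccc(CNC(=O)Nc2ccccc2)c(=O)n1Cc1ccc(-c2ccccc2-c2nn[nH]n2)cc1` gives 30 nM in this assay, and compound 3 `CCCCNC(=O)NCc1ccc(CCCC)n(Cc2ccc(-c3ccccc3-c3nn[nH]n3)cc2)c1=O` gives 10 nM. Compound 3 thus stands second highest of the three numbers: a 3.0-fold lower number from compound 2 to compound 3 (0.48 log units; beyond the scatter), while a 10-fold higher number from compound 1 to compound 3 (1.00 log units; beyond the scatter). Compound 4 `CCCCc1ccc(CNC(C)=O)c(=O)n1Cc1ccc(-c2ccccc2-c2nn[nH]n2)cc1` differs from compound 3 in one place: methyl in place of butylamino on a carbonyl carbon. Within the data shown here, no measured step alters the carbonyl carbon itself; the nearest comparisons are a 10-fold higher number from compound 1 to compound 3 (1.00 log units; beyond the scatter) and a 3.0-fold lower number from compound 2 to compound 3 (0.48 log units; beyond the scatter), both of which show that what sits on this side chain moves the number by a modest amount. Compound 4 is therefore expected to show a modest step toward a higher number, a 6.0-fold higher number from compound 3 to compound 4 (0.78 log units; beyond the scatter). The estimate for compound 4 in this assay is 60 nM, with a range from 15 nM to 250 nM.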

Compound 4, half-maximal inhibitory concentration: 3 nM
Estimate against measurement, compound 4: 20-fold (1.30 log units) above; the measured number lies below the stated range.
By their numbers in this assay, from the lowest: compound 1; then compound 4; then compound 3; then compound 2.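

In this assay, the carbonyl carbon does not need a second nitrogen substituent for a low number: methyl in place of butylamino gives a gain (a 3.3-fold lower number from compound 3 to compound 4 (0.52 log units; beyond the scatter)), and methyl in place of anilino gives a larger one (a 10-fold lower number from compound 2 to compound 4 (1.00 log units; beyond the scatter)). Even so, acetyl on the amine nitrogen does not match benzyl (a 3.0-fold higher number from compound 1 to compound 4 (0.48 log units; beyond the scatter)). Nothing given here accounts for these steps. What the compounds leave open is how a propanoyl or benzoyl group would read on that amine nitrogen, and whether a plain ethyl group there would match acetyl or benzyl.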